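Changing the urea aryl group of compound 1

The compounds below may be only part of what the source reports. "The series", "measured", "known", "first", "only" and "open" are said of these compounds alone.

In a functional assay on HCC827 cells (Homo sapiens) for inhibition, read by MTT assay, with a stated time of 48 h, tested at 10 uM (a higher number here means more inhibition at the concentration tested (going by the name of the read-out), a lower number less inhibition), compound 1 `COc1cc(Br)ccc1Nc1cc(NC(=O)Nc2c(Cl)cccc2Cl)ncn1` gives 42.7%, the lowest of the three numbers shown. Compound 2 `Cc1ccc(Nc2cc(NC(=O)Nc3c(Cl)cccc3Cl)ncn2)cc1F` gives 85.3% and compound 3 `O=C(Nc1cc(Nc2ccc(F)c(Cl)c2)ncn1)Nc1c(Cl)cccc1Cl` gives 53.7%; the steps of a number 42.6 percentage points higher from compound 1 to compound 2 (beyond the scatter) and a number 11 percentage points higher from compound 1 to compound 3 (beyond the scatter) both change the aryl group on the nitrogen attached to the aromatic core. Compound 4 `COc1cc(NC(=O)Nc2cc(Nc3ccc(Br)cc3OC)ncn2)cc(OC)c1` differs from compound 1 elsewhere: 3,5-dimethoxyphenyl in place of 2,6-dichlorophenyl on an amide-type nitrogen on an amide-type nitrogen whose other neighbour is a carbonyl carbon. Within the data shown here, no measured step touches that position, so the three steps give no direct guide to its size or direction. With no evidence for a gain, compound 4 is expected to give 32%, within 5% to 65%, an estimated step of a number 10.7 percentage points lower from compound 1 to compound 4 (beyond the scatter).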

Compound 4, a percentage reported as inhibition, at one concentration (the size of the read-out at that concentration, not a potency): 57.7%
Compound 4: the middle estimate sits 25.7 percentage points below what was measured; the measured number falls inside the stated range.
By their numbers in this assay, from the lowest: compound 1; then compounds 3 and 4 (each within the scatter of the next); then compound 2.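

Replacing 2,6-dichlorophenyl with 3,5-dimethoxyphenyl on the amide-type nitrogen gives a number 15 percentage points higher from compound 1 to compound 4 (beyond the scatter) in this assay. This shows that the second aryl group also affects inhibition and that 2,6-dichlorophenyl is not required for the level seen with compound 1. The data shown offer no explanation for this gain.

From the compounds shown here alone, it remains open whether the same swap would also raise the number for compound 2, which carries 3-fluoro-4-methylphenyl. It is also unknown how a plain phenyl group, or a phenyl ring carrying a morpholine, would compare at this position.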